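Methyl in Place of Chloro: What to Expect for Compound 4

The source may hold more compounds than are shown below. What is called first, only, known or untested is meant among the compounds shown, and "the series" means these compounds.

Of the compounds shown here, three sharing one core have been measured in a functional assay on B16-F10 cells (Mus musculus) for inhibition, read by MTT assay, with a stated time of 48 h; a lower number here means a stronger inhibitor, a higher number a weaker inhibitor. Compound 1 `O=C(/C=C/c1ccccc1)Nc1ccc2ncnc(Nc3cccc(Br)c3)c2c1` gives 1.45 ug/mL. Compound 2 `O=C(/C=C/c1cccs1)Nc1ccc2ncnc(Nc3cccc(Br)c3)c2c1` gives 2.51 ug/mL. Compound 3 `O=C(/C=C/c1ccc(Cl)cc1)Nc1ccc2ncnc(Nc3cccc(Cl)c3)c2c1` gives 9.97 ug/mL, the highest of the three numbers; its gaps to compound 2 and to compound 1 both lie beyond the scatter, so compound 3 is the weakest inhibitor among the measured set.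

Compound 4 `Cc1ccc(/C=C/C(=O)Nc2ccc3ncnc(Nc4cccc(Cl)c4)c3c2)cc1` differs from compound 3 by methyl in place of chloro on an aromatic carbon, on an aromatic carbon of a six-membered aromatic ring of carbon only, para to a large group. Among the compounds with values here, no measured pair tests this exact swap. Within the data shown here, the only single-point step available is a 1.7-fold higher number from compound 1 to compound 2 (0.24 log units; within the scatter), which alters the same terminal ring and stayed within the scatter. Compounds 1 and 3 differ in two places at once, so their values cannot isolate what the chloro contributes. Among the measured compounds shown here, the one bearing step therefore suggests that a change at that ring moves the number little, and the expected step of a 1.2-fold lower number from compound 3 to compound 4 (0.10 log units; within the scatter) is none beyond the scatter, in either direction. Compound 4 is accordingly estimated at 8 ug/mL in this assay, with a range from 3 ug/mL to 20 ug/mL.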

Compound 4, half-maximal inhibitory concentration: 2.02 ug/mL
The estimate for compound 4 lay 4.0-fold (0.60 log units) above the measured number; measured number below the stated range.
By their numbers in this assay, from the lowest: compounds 1, 4 and 2 (each within the scatter of the next); then compound 3.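

Exchanging one heavy atom for another on the 4-chlorophenyl group, with no change in the counted hydrogen-bond donors or acceptors, produces a 4.9-fold lower number from compound 3 to compound 4 (0.69 log units; beyond the scatter) in this assay and shows that the number responds to what sits at this place, para to a large group. Within the data shown here, the only earlier step at this end of the molecule replaced the whole phenyl ring with a thiophen-2-yl ring and gave a result within the scatter (a 1.7-fold higher number from compound 1 to compound 2 (0.24 log units; within the scatter)), so that step gave no sign that a single-atom change here could matter this much. Nothing available explains why methyl and chloro differ here.

This single pair cannot tell whether chloro raises the number or methyl lowers it, and settling that would take a compound with plain hydrogen at this place and everything else as in compound 3. As far as these compounds go, how far the trend extends also remains open, and groups such as methoxy, an amine, a carboxylic acid or a longer chain such as ethyl at the same place would begin to show which groups the number tolerates.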